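This account rests on a few compounds, and the source may have more. Where it says the series, first, only, none or still open, it means among the compounds named here.

Compound 1 `CO[C@]1(c2ccc(OCc3c(-c4c(Cl)cccc4Cl)noc3C3CC3)cc2Cl)C[C@H](c2cccc(C(=O)O)c2)C1` has the highest number of the three compounds measured in an assay on isolated protein for agonist activity at Bile acid receptor (Homo sapiens), read by FRET (on this read-out lower numbers stand for an effect already at smaller amounts and higher numbers for an effect only at larger amounts of compound), where compound 1 gives 79 nM. Compound 2 `CS(=O)(=O)NC(=O)c1ccc([C@@H]2C[C@H]2c2ccc(OCc3c(-c4c(Cl)cccc4Cl)noc3C3CC3)cc2Cl)cc1` gives 48 nM in this assay, a value within the scatter of that of compound 1, so no order between these two can be stated. Compound 3 `Cn1nc(C(=O)O)c2ccc([C@H]3C[C@](O)(c4ccc(OCc5c(-c6c(Cl)cccc6Cl)noc5C5CC5)cc4Cl)C3)cc21` gives 19 nM in this assay, a number that sits beyond the scatter below compound 1. Compound 4 `O=C(O)c1cccc([C@H]2C[C@](OCCO)(c3ccc(OCc4c(-c5c(Cl)cccc5Cl)noc4C4CC4)cc3Cl)C2)c1` is not yet measured; it differs from compound 1 in a single place: hydroxymethyl in place of hydrogen on a saturated chain carbon bound to an oxygen on a saturated carbon. For the measured compounds named here, no measured pair shows this change, so the step is expected to be small, most likely none beyond the scatter, with at most a slight lean toward a lower number: a 1.3-fold lower number from compound 1 to compound 4 (0.12 log units; within the scatter). Compound 4 is therefore estimated at 60 nM in this assay, within 25 nM to 150 nM.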

Compound 4, half-maximal effective concentration: 373 nM
The estimate for compound 4 lay 6.2-fold (0.79 log units) below the measured number, outside the stated range (above it).
By their numbers in this assay, from the lowest: compound 3; then compounds 2 and 1 (each within the scatter of the next); then compound 4.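

In this assay, for the compounds shown here, the change from methoxy to 2-hydroxyethoxy gives a 4.7-fold higher number from compound 1 to compound 4 (0.67 log units; beyond the scatter) and thus provides the first measured step at this position, where the added hydroxymethyl moves the number beyond the scatter. No measurement here accounts for this step. The compounds shown leave open whether the added chain length or the terminal hydroxyl carries the step, a question that an ethoxy group at this place would address. They also leave open how a terminal amine or a terminal carboxylic acid on this chain would read.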